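The source may report more compounds than this note shows. Statements on the series, on what has been measured and on what is new or still open speak of the compounds shown alone.

In a functional assay on DU-145 cells (Homo sapiens) for cytotoxicity (on this read-out lower numbers stand for stronger inhibition of growth and higher numbers for weaker inhibition of growth), compound 3 (`COc1ccc(C2=C(c3ccc(SC)cc3)CC3CCCN3C2=O)cc1`) gives 900 nM. This lies within the scatter of compound 2 (`CSc1ccc(C2=C(c3ccc(C)c(C)c3)C(=O)N3CCCC3C2)cc1`) at 500 nM, and clearly under compound 1 (`COc1ccc(C2=C(c3ccc(SC)cc3)CC3CCCN3C2=O)cc1O`) at 6000 nM.

Compound 4 (`CSc1ccc(C2=C(c3ccc(C)cc3)C(=O)N3CCCC3C2)cc1`) has methyl in place of methoxy on an aromatic carbon, para to a large group (methyl in place of methoxy on an aromatic carbon). The same difference, cut one bond further out, reads 4-methoxyphenyl to 4-methylphenyl.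

For the measured compounds named here, no measured step isolates this swap. The closest is 3,4-dimethylphenyl to 4-methoxyphenyl, which gives a 1.8-fold higher number from compound 2 to compound 3 (0.26 log units; within the scatter). Compound 4 carries a 4-methylphenyl group, so it differs from each of these two compounds only on that same aryl group. The other two steps are both large or modest: a 12-fold lower number from compound 1 to compound 2 (1.08 log units; beyond the scatter) and a 6.7-fold lower number from compound 1 to compound 3 (0.82 log units; beyond the scatter). Both start from the 3-hydroxy-4-methoxyphenyl group of compound 1, and that hydroxy is absent from compound 3 and compound 4, so they say little about the present change.

In this assay, no shift beyond the scatter is therefore expected, at most a slight drift towards compound 2. The expected step is a 1.4-fold lower number from compound 3 to compound 4 (0.14 log units; within the scatter), an estimate that stays within the scatter. For compound 4 the estimated value is 650 nM, with an expected range of 250 nM to 1600 nM.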

Compound 4, concentration for 50% growth inhibition: 600 nM
For compound 4 the middle estimate is 1.1-fold (0.03 log units) above the measured one, within the range that was stated.
By their numbers in this assay, from the lowest: compounds 2, 4 and 3 (each within the scatter of the next); then compound 1.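

In this assay, the change of methoxy to methyl on an aromatic carbon, para to a large group, can now be read alone: a 1.5-fold lower number from compound 3 to compound 4 (0.18 log units; within the scatter) shows that 4-methoxyphenyl and 4-methylphenyl cannot be told apart here, even though the hydrogen-bond acceptor of the methoxy leaves with the change. The second methyl of the 3,4-dimethylphenyl group is equally unresolved, with a 1.2-fold higher number from compound 2 to compound 4 (0.08 log units; within the scatter) as its step, whereas a 10-fold lower number from compound 1 to compound 4 (1.00 log units; beyond the scatter) sets the 3-hydroxy-4-methoxyphenyl group of compound 1 apart from the 4-methylphenyl group as well, so among these four compounds only compound 1 stands off from the others. No measurement at hand accounts for any of these steps.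

Open, on these data alone, is how an amine, a carboxylic acid or a longer chain on this same aromatic carbon would read in this assay, since only methoxy and methyl can be compared there so far. Also open, as far as these compounds go, is whether a fluorine or an amine in the place of the hydroxy of compound 1 would give a step of similar size.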